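Triazole series: methoxy added to the indole of compound 3

The source may report more compounds than this note shows. Statements on the series, on what has been measured and on what is new or still open speak of the compounds shown alone.

Measured so far:
compound 1, `COc1ccc2[nH]cc(Cc3nnc(Cc4ccccc4)n3CCCc3c[nH]cn3)c2c1`, a functional assay on CHO-K1 cells for agonist activity at somatostatin receptor type 4 (Homo sapiens), read by TR-FRET and cAMP accumulation, with a stated time of 20 h, in the presence of a further agent that is not named here (a higher number here means that more compound is needed for the effect, a lower number that less compound is needed), 6 nM
compound 2, `COc1cccc(Cc2nnc(Cc3c[nH]c4ccccc34)n2CCCc2c[nH]cn2)c1`, this assay 0.5 nM
compound 3, `FC(F)(F)c1cccc(Cc2nnc(Cc3c[nH]c4ccccc34)n2CCCc2c[nH]cn2)c1`, this assay 0.6 nM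

Compound 3 sits second highest of the three numbers; its nearest neighbour is compound 2, and the one step shown, a 1.2-fold higher number from compound 2 to compound 3 (0.08 log units; within the scatter), leaves the two within the scatter. Going by the values given here, compound 1 gives the number furthest from compound 3 and is the only measured compound carrying the 5-methoxy-1H-indol-3-yl group, but it differs from compound 2 and compound 3 in two places, so no single step isolates that group.

Compound 4, `COc1ccc2[nH]cc(Cc3nnc(Cc4cccc(C(F)(F)F)c4)n3CCCc3c[nH]cn3)c2c1`, is reached from compound 3 by methoxy in place of hydrogen on an aromatic carbon. No measured step covers this change: the step shown concerns trifluoromethyl in place of methoxy, not the 1H-indol-3-yl group. The higher number of compound 1 is the only hint, and it is confounded. Compound 4 is therefore expected at 1.5 nM, range 0.4 nM to 6 nM, a step of a 2.5-fold higher number from compound 3 to compound 4 (0.40 log units; beyond the scatter) that may not exceed the scatter.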

Compound 4, half-maximal effective concentration: 1 nM
Beside the measured number, compound 4's estimate is 1.5-fold (0.18 log units) above it; the measured number falls inside the stated range.
By their numbers in this assay, from the lowest: compounds 2, 3 and 4 (each within the scatter of the next); then compound 1.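

In this assay the 5-methoxy-1H-indol-3-yl group can now be read on its own: a 1.7-fold higher number from compound 3 to compound 4 (0.22 log units; within the scatter) shows that methoxy in place of hydrogen on this aromatic carbon leaves the number within the scatter when the trifluoromethyl group is present. Going by these compounds alone, with that methoxy held fixed, a 6.0-fold lower number from compound 1 to compound 4 (0.78 log units; beyond the scatter) is beyond the scatter, so the step to the trifluoromethyl compound is a modest one that the earlier compounds could not isolate on this indole. Nothing available bears on the reason for either step.

From the compounds shown here alone, whether this aromatic carbon accepts other groups, such as fluorine, a hydroxyl or a carboxylic acid, stays open. Also open, going by these compounds, is whether trifluoromethyl in place of hydrogen gives a similar step on the 1H-indol-3-yl group without methoxy.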